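From compound 2 to its chloro relative, compound 4

This account rests on a few compounds, and the source may have more. Where it says the series, first, only, none or still open, it means among the compounds named here.

- compound 1 `Cc1ccc(NC(=O)/C=C/c2ccccc2)c(C(N)=O)c1`: 65.4%
- compound 2 `NC(=O)c1cc(Br)ccc1NC(=O)/C=C/c1ccccc1`: 62.4%
- compound 3 `Cc1cccc(/C=C/C(=O)Nc2ccc(Cl)cc2C(N)=O)c1`: 37.8%

In a functional assay on K562 cells (Homo sapiens) for antiproliferative activity, read by trypan blue exclusion, with a stated time of 48 h, tested at 10 uM (a higher number here means more inhibition of growth at the concentration tested, a lower number less inhibition of growth), compound 2 gives 62.4%. That number is level with compound 1 within the scatter, while compound 3 lies lower, beyond the scatter.

The next compound, compound 4 `NC(=O)c1cc(Br)ccc1NC(=O)/C=C/c1ccccc1Cl`, keeps the structure of compound 2 except for one change: chloro in place of hydrogen on an aromatic carbon, ortho to a large group, which turns phenyl into 2-chlorophenyl (chloro in place of hydrogen on an aromatic carbon).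

Among the measured compounds shown here, the only measured step is a different change, bromo in place of methyl, and it gives a number 3 percentage points lower from compound 1 to compound 2 (within the scatter). For the measured compounds named here, no measured pair tests chloro in place of hydrogen, so that step offers only weak guidance. Compound 3, at 37.8%, shows that numbers in this small set can lie well under that of compound 2, so a small downward step seems somewhat likelier than a rise. The expected step is a number 8.4 percentage points lower from compound 2 to compound 4 (within the scatter). For compound 4 the estimate is 54%, with an expected range of 32% to 72%.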

Compound 4, percent growth inhibition at one concentration: 59%
Compound 4: middle estimate off by 5 percentage points, on the low side; the range from low to high includes it.
By their numbers in this assay, from the lowest: compound 3; then compounds 4, 2 and 1 (each within the scatter of the next).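

In this assay, among the compounds shown here, the change from phenyl to 2-chlorophenyl gives a number 3.4 percentage points lower from compound 2 to compound 4 (within the scatter) and is the first step measured on this ring of the shared core. In this pair, the aromatic carbon ortho to a large group can carry a chloro with no change beyond the scatter, although one pair cannot show how other groups would behave there. Nothing available explains why the chloro leaves the number within the scatter.

On these data alone, it remains open whether an amine, a methoxy group or a carboxylic acid on this same carbon would also stay level with compound 2. As far as these compounds go, the effect of chloro on the other carbons of this ring, with the rest of compound 2 unchanged, also remains open.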